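A few compounds are considered here, and "the series" means these few. Any claim that something is new, unique, unknown or untested is made for them only; others in the source may bear on it.

Series notes on the permeability set. Compound 1 `COc1ccc(Oc2ccc3c(NCCCNCc4cc(F)ccc4OC)ccnc3c2)cc1` is the reference point. In an ADME assay for permeability, using PAMPA, with a stated time of 30 min, at pH 7.4 (on this read-out lower numbers stand for lower permeability and higher numbers for higher permeability), compound 1 gives 317 10^-6 cm/s, the highest of the three numbers in hand. Compound 2 `COc1ccc(-c2ccc3c(NCCCNCc4cc(F)ccc4OC)ccnc3c2)cc1` gives 237 10^-6 cm/s in this assay, and the step of a 1.3-fold lower number from compound 1 to compound 2 (0.13 log units; within the scatter) lies within the scatter. Compound 3 `COc1ccc(F)cc1CNCCCNc1ccnc2cc(CC3CCCCC3)ccc12` gives 23 10^-6 cm/s in this assay; the steps of a 14-fold lower number from compound 1 to compound 3 (1.14 log units; beyond the scatter) and a 10-fold lower number from compound 2 to compound 3 (1.01 log units; beyond the scatter) are large and beyond the scatter.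

Compound 4 `COc1ccc(Oc2ccc3c(NCCCNCc4ccco4)ccnc3c2)cc1` is not yet measured. It differs from compound 1 by furan-2-yl in place of 5-fluoro-2-methoxyphenyl on a saturated chain carbon bound to an amine nitrogen. All three measured steps change the group on the aromatic carbon and leave the group on the saturated chain carbon bound to an amine nitrogen untouched, so none of them bears directly on this change. What the measured steps do show is that the read-out can move by a large step (compound 3) or hardly at all (compound 2) when the aromatic-carbon group is exchanged; nothing in hand tests the other end of the chain. For the measured compounds named here, with no direct precedent, the expected step of a 1.6-fold lower number from compound 1 to compound 4 (0.20 log units; within the scatter) is taken as modest, more likely downward than upward, and not clearly beyond the scatter. Compound 4 is estimated at 200 10^-6 cm/s in this assay, with a range from 100 10^-6 cm/s to 400 10^-6 cm/s.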

Compound 4, apparent permeability: 317 10^-6 cm/s
For compound 4 the middle estimate is 1.6-fold (0.20 log units) below the measured one; the measured number falls inside the stated range.
By their numbers in this assay, from the lowest: compound 3; then compounds 2, 1 and 4 (each within the scatter of the next).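

For the compounds shown here, the step of no change at the digits printed from compound 1 to compound 4 (within the scatter) in this assay is the first reading at this end of the molecule, on a saturated chain carbon bound to an amine nitrogen, whereas every earlier step exchanged the group on the aromatic carbon. With 4-methoxyphenoxy held in place on the aromatic carbon, a six-membered aromatic ring of carbon only with 9 heavy atoms gives way to a five-membered aromatic ring with 1 hetero atom and 5 heavy atoms, and the two compounds stay within the scatter of each other, so this one pair gives no sign that the read-out depends on the fluorine or the methoxy group of the group that leaves. No measurement in hand accounts for this result.

As far as these compounds go, the pair rests on a single group at the aromatic carbon, so it remains open whether the same exchange would read alike with cyclohexylmethyl there, as in compound 3, where the number is far lower. Also open, from the compounds shown here alone, is how the read-out responds at the chain carbon to a group of another kind, such as a carboxylic acid, a second amine or a saturated cyclohexyl ring.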